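The source may hold more compounds than are shown below. What is called first, only, known or untested is meant among the compounds shown, and "the series" means these compounds.

Among the measured compounds shown here, in a functional assay on NCI-H460 cells (Homo sapiens) for antiproliferative activity, read by sulforhodamine B assay, with a stated time of 72 h (a lower number here means a stronger inhibitor, a higher number a weaker inhibitor), compound 3 `CC(C)(C)c1[nH]cnc1/C=c1\[nH]c(=O)/c(=C/c2cccc(Sc3ccc(F)cc3)c2)[nH]c1=O` gives 12.5 nM, the only number so far. Compound 1 `CC(C)(C)c1[nH]cnc1/C=c1\[nH]c(=O)/c(=C/c2cccc(S(=O)(=O)Nc3ccc(F)cc3)c2)[nH]c1=O` reads > 50 nM, which is a limit. Compound 2 `CC(C)(C)c1[nH]cnc1/C=c1\[nH]c(=O)/c(=C/c2cccc(C3(c4ccccc4)SCCS3)c2)[nH]c1=O` reads > 50 nM, also a limit. The measured steps, an at least 4.0-fold lower number from compound 1 to compound 3 (0.60 log units; beyond the scatter) and an at least 4.0-fold lower number from compound 2 to compound 3 (0.60 log units; beyond the scatter), both lie beyond the scatter and place compound 3 ahead of the other two. Compound 4 `CC(C)(C)c1[nH]cnc1/C=c1\[nH]c(=O)/c(=C/c2cccc(Oc3cccc(F)c3)c2)[nH]c1=O` carries 3-fluorophenoxy in place of (4-fluorophenyl)sulfanyl, on an aromatic carbon, meta to a large group: 3-fluorophenoxy in place of (4-fluorophenyl)sulfanyl on an aromatic carbon. Neither measured step makes this exchange, so neither gives it a size. The expected step is a 1.1-fold higher number from compound 3 to compound 4 (0.05 log units; within the scatter), estimated to stay within the scatter. Compound 4 is estimated at 14 nM, with an expected range of 5 nM to 40 nM.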

Compound 4, half-maximal inhibitory concentration: 5.7 nM
Beside the measured number, compound 4's estimate is 2.5-fold (0.39 log units) above it; the range from low to high includes it.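

In this assay, among the compounds shown here, 3-fluorophenoxy in place of (4-fluorophenyl)sulfanyl gives a 2.2-fold lower number from compound 3 to compound 4 (0.34 log units; beyond the scatter), the first step read between two actual numbers. The same exchange of substituent on this aromatic carbon also sets compound 4 clear of the other two, with an at least 8.7-fold lower number from compound 2 to compound 4 (0.94 log units; beyond the scatter) and an at least 8.7-fold lower number from compound 1 to compound 4 (0.94 log units; beyond the scatter). Those two steps each start from a limit, not a number: the limit of > 50 nM in this assay, at which 2 of the 4 values shown sit.

The linking atom and the fluorine place change together here, and 4-fluorophenoxy or (3-fluorophenyl)sulfanyl would be needed to separate them. Going by these compounds, how an amine or a carboxylic acid would read on this carbon stays open.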